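Swapping the amide side chain for an aryl ester

The source may hold more compounds than are shown below. What is called first, only, known or untested is meant among the compounds shown, and "the series" means these compounds.

Compound 1 `CCn1c(C(=O)NCCN(C)C)ccc1C(CC)(CC)c1ccc(OCC(=O)C(C)(C)C)c(C)c1` gives 77 nM in an assay on HL-60 cells for agonist activity at vitamin D3 receptor (Homo sapiens), read by microscopy, with a stated time of 96 h; a higher number here means that more compound is needed for the effect, a lower number that less compound is needed.
Compound 2 `CCn1c(C(=O)N(CCC#N)CCC#N)ccc1C(CC)(CC)c1ccc(OCC(O)C(C)(C)C)c(C)c1` gives 97 nM in this assay.
Compound 3 `CCn1c(C(=O)N(C)CC(=O)O)ccc1C(CC)(CC)c1ccc(OCC(O)C(C)(C)C)c(C)c1` gives 740 nM in this assay.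

Compound 1 has the lowest of the three numbers; compound 2 sits within the scatter of it, while compound 3 lies well beyond it. Compound 4 `CCOC(=O)c1ccc(OC(=O)c2ccc(C(CC)(CC)c3ccc(OCC(=O)C(C)(C)C)c(C)c3)n2CC)cc1` differs from compound 1 in one place: 4-(ethoxycarbonyl)phenoxy in place of (2-(dimethylamino)ethyl)amino on a carbonyl carbon. Among the compounds with values here, the only measured step at the same carbonyl carbon is a 7.6-fold higher number from compound 2 to compound 3 (0.88 log units; beyond the scatter), where one group on that carbon was exchanged for another and the number rose. Within the data shown here, no measured step makes a change of the present kind, so the direction is uncertain, but the one comparison at this position leans towards a higher number. Compound 4 is therefore expected to shift as a 3.2-fold higher number from compound 1 to compound 4 (0.51 log units; beyond the scatter). The estimate for compound 4 in this assay is 250 nM, between 50 nM and 1500 nM.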

Compound 4, half-maximal effective concentration: 45600 nM
Beside the measured number, compound 4's estimate is 180-fold (2.26 log units) below it; measured number outside the range, above it.
By their numbers in this assay, from the lowest: compounds 1 and 2 (each within the scatter of the next); then compound 3; then compound 4.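

In this assay the step to 4-(ethoxycarbonyl)phenoxy on the carbonyl carbon is a 590-fold higher number from compound 1 to compound 4 (2.77 log units; beyond the scatter) and far exceeds the earlier 7.6-fold higher number from compound 2 to compound 3 (0.88 log units; beyond the scatter) at that same carbon. Within the data shown here, the group on this carbon can therefore move the number much further than the earlier compounds showed. No available evidence accounts for the size of this step. The compounds shown do not separate the contributions of the ester link, the aromatic ring and the ethoxycarbonyl group. A plain phenoxy group, or a carboxylic acid in place of the ethoxycarbonyl, would help to separate them.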